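Moving a fluorine around the ring: compound 1 to compound 4

This account rests on a few compounds, and the source may have more. Where it says the series, first, only, none or still open, it means among the compounds named here.

Compound 1 `C[C@H](c1ccc(C(=O)NCCC(=O)O)cc1)N1C(=O)C(c2ccc(F)cc2)=N[C@]12CC[C@@H](C(C)(C)C)CC2` was tested in a functional assay on CHO cells for antagonist activity at Glucagon receptor (Homo sapiens), read by cAMP accumulation, with stated times of 30 min and 45 min (on this read-out higher numbers stand for weaker inhibition and lower numbers for stronger inhibition), and gave 430 nM. Among the three compounds measured, this is the second highest number. Compound 3 `CC(C)(C)CC[C@H](c1ccc(C(=O)NCCCC(=O)O)cc1)N1C(=O)C(c2cc(Cl)cc(Cl)c2)=N[C@]12CC[C@@H](C(C)(C)C)CC2` gives 350 nM, a number within the usual scatter of that of compound 1, so the two cannot be told apart. Compound 2 `CC(C)(C)[C@H]1CC[C@]2(CC1)N=C(c1ccc(OC(F)(F)F)cc1)C(=O)N2Cc1ccc(C(=O)NCCC(=O)O)cc1` gives 1900 nM, a number clearly higher than that of compound 1 and beyond the scatter, meaning weaker inhibition.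

Compound 4 `C[C@H](c1ccc(C(=O)NCCC(=O)O)cc1)N1C(=O)C(c2ccccc2F)=N[C@]12CC[C@@H](C(C)(C)C)CC2` has the same atoms as compound 1, joined differently: 2-fluorophenyl in place of 4-fluorophenyl on a carbon with a double bond to nitrogen. Within the data shown here, no measured pair in this set shows such a rearrangement on its own, so there is no direct guide to its size or direction. A change of this kind is expected to move the number only modestly, most likely not beyond the scatter, with a slight lean toward weaker inhibition. The expected step from compound 1 to compound 4 is a 1.4-fold higher number from compound 1 to compound 4 (0.14 log units; within the scatter). Compound 4 is estimated to give 600 nM in this assay, within a range from 250 nM to 1500 nM.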

Compound 4, half-maximal inhibitory concentration: 350 nM
Estimate against measurement, compound 4: 1.7-fold (0.23 log units) above; the measured number falls inside the stated range.
By their numbers in this assay, from the lowest: compounds 3, 4 and 1 (each within the scatter of the next); then compound 2.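

Placing 2-fluorophenyl in place of 4-fluorophenyl, on the carbon with a double bond to nitrogen, gives a 1.2-fold lower number from compound 1 to compound 4 (0.09 log units; within the scatter) in this assay. Among these compounds, this is the first comparison here in which only one place differs, and it shows that, with the rest of compound 1 held fixed, this shift of the fluorine leaves a difference that cannot be told from the scatter. Nothing available explains why the two numbers stay so close.

From the compounds shown here alone, whether the fluorine itself matters at this carbon remains open, since a plain phenyl group would be needed to answer that. A larger group such as 2-chlorophenyl or 2-methoxyphenyl would show whether this part of the ring accepts more than a single fluorine atom.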